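The source may hold more compounds than are shown below. What is called first, only, known or untested is meant among the compounds shown, and "the series" means these compounds.

Working notes on the series. Compound 1 `CC1=C(C(=O)NC(C)C)C(c2cccs2)NC(=O)N1` gives 1% in an assay on membranes from HeLa cells for displacement of a labelled ligand from adenosine receptor A3 (Homo sapiens), read by scintillation counting, with a stated time of 180 min, tested at 1 uM (a higher number here means more inhibition at the concentration tested (going by the name of the read-out), a lower number less inhibition), and stands level with compound 2 `CC1=C(c2ncc(C)o2)C(c2cccs2)NC(=O)N1`, which in this assay gives 1%. Among the measured compounds shown here, the only measured step, no change at the digits printed from compound 1 to compound 2 (within the scatter), replaces the whole group on a double-bonded ring carbon and leaves the read-out where it was, within the scatter. Compound 3 `CC1=C(C(=O)OCC2CC2)C(c2cccs2)NC(=O)N1` has not yet been measured; it differs from compound 1 as follows: cyclopropylmethoxy in place of isopropylamino on a carbonyl carbon. The step from compound 1 to compound 2 is the only one that bears on this change, and it showed no movement at all from an already low value, so no step beyond the scatter is expected for compound 3 either. On that basis compound 3 is estimated at 3%, with a range from -8% to 15%. The expected step of a number 2 percentage points higher from compound 1 to compound 3 (within the scatter) would thus stay within the scatter.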

Compound 3, a percentage reported as inhibition, at one concentration (the size of the read-out at that concentration, not a potency): 1%
Compound 3: the middle estimate sits 2 percentage points above what was measured, and the stated range covers the measured number.
By their numbers in this assay, from the lowest: compounds 1, 2 and 3 (each within the scatter of the next).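

Keeping the carbonyl and changing only the group on it, cyclopropylmethoxy in place of isopropylamino gives no change at the digits printed from compound 1 to compound 3 (within the scatter) in this assay. Unlike the earlier step, which replaced the whole group, this one isolates the part on the carbonyl carbon: the hydrogen-bond donor of isopropylamino leaves, and a hydrogen-bond acceptor and a three-membered ring enter, with no movement in the read-out. With all the compounds shown at the same low level, this says only that neither group lifts the read-out, and no measurement available here explains that result.

From the compounds shown here alone, it remains open whether any group at this position can raise the read-out, for example a phenyl ring, a carboxylic acid or a longer chain on the carbonyl carbon. The compounds shown also leave open whether the thiophene-bearing shared core can reach a higher level at all.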